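A few compounds are considered here, and "the series" means these few. Any claim that something is new, unique, unknown or untested is made for them only; others in the source may bear on it.

Measured compounds:
Compound 1, `Cc1ccc(-c2nc(N)c3cc(C(C)c4ccccc4)sc3n2)o1`, gives 439 nM in a functional assay on CHO-K1 cells for antagonist activity at adenosine receptor A1 (Homo sapiens), read by a beta-galactosidase reporter and cAMP accumulation, with stated times of 15 min and 6 h; on this read-out lower numbers stand for stronger inhibition and higher numbers for weaker inhibition.
Compound 2, `N#Cc1cccc(-c2nc(N)c3cc(Cc4ccccc4)sc3n2)c1`, gives 222 nM in this assay.
Compound 3, `N#Cc1cccc(-c2nc(N)c3cc(Cc4ccccc4Cl)sc3n2)c1`, gives 24.8 nM in this assay.

Compound 3 stands at the lowest number of the three; compound 2 sits at a higher number and compound 1 higher still. Within the data shown here, the one single-point step among the measured compounds runs from compound 2 to compound 3, a 9.0-fold lower number from compound 2 to compound 3 (0.95 log units; beyond the scatter), and that chloro is exactly what leaves in the change now considered.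

Compound 4, `CC(c1ccccc1)c1cc2c(N)nc(-c3cccc(C#N)c3)nc2s1`, differs from compound 3 by 1-phenylethyl in place of 2-chlorobenzyl on an aromatic carbon. Two things happen at once: the chlorine that gave compound 3 its advantage over compound 2 is gone, and a methyl now sits on the benzylic carbon. Only the first part is covered by a measured step; the second has no isolated comparison, since compound 1 carries the 1-phenylethyl group but also a different aryl group on the core, so its value cannot be separated into two effects.

The loss of the chloro is therefore expected to cost most of what the step from compound 2 to compound 3 gained, giving a 10-fold higher number from compound 3 to compound 4 (1.00 log units; beyond the scatter). Compound 4 is estimated at 250 nM, with a range from 80 nM to 800 nM.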

Compound 4, inhibition constant: 1770 nM
The estimate for compound 4 lay 7.1-fold (0.85 log units) below the measured number; measured number outside the range, above it.
By their numbers in this assay, from the lowest: compound 3; then compounds 2 and 1 (each within the scatter of the next); then compound 4.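

In this assay, the methyl on the saturated chain carbon bound to two aromatic carbons can now be read alone, and it carries a clear cost (an 8.0-fold higher number from compound 2 to compound 4 (0.90 log units; beyond the scatter)), which compound 1 could not show while it also differed in its aryl group. At this position next to the ring sulfur, the full exchange of 2-chlorobenzyl for 1-phenylethyl is a large step (a 71-fold higher number from compound 3 to compound 4 (1.85 log units; beyond the scatter)), so the position responds both to what is on the aromatic ring of the substituent and to what is on its chain carbon. With 1-phenylethyl held constant, the aryl group on the core also shifts the number, 3-cyanophenyl in place of 5-methylfuran-2-yl being the weaker choice of the two (a 4.0-fold higher number from compound 1 to compound 4 (0.61 log units; beyond the scatter)).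

Nothing available gives a reason for any of these steps. On these data alone, it remains open what a 1-(2-chlorophenyl)ethyl group would give at this position, and whether a fluoro or methoxy group on the benzyl ring would match the chloro of compound 3.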